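Compound 3 without its allyloxy group

The compounds below may be only part of what the source reports. "The series", "measured", "known", "first", "only" and "open" are said of these compounds alone.

Measured in an ADME assay on HT-29 cells (Homo sapiens) for cytotoxicity, read by MTT assay, with a stated time of 72 h; on this read-out lower numbers stand for stronger inhibition and higher numbers for weaker inhibition:
compound 1 `COc1ccc(C2=C(c3cc(OC)c(OC)c(OC)c3)C(=O)CC2C)cc1C(=O)O`: > 100 ug/mL (a limit)
compound 2 `COc1ccc(C2=C(c3cc(OC)c(OC)c(OC)c3)C(=O)C(OC(C)=O)C2)cc1`: < 1 ug/mL (a limit)
compound 3 `C=CCOc1cc(C2=C(c3cc(OC)c(OC)c(OC)c3)C(=O)C(O)C2)ccc1OC`: > 100 ug/mL (a limit)

All three results are limits, so no exact gap between any two compounds can be read from them. Compound 3 gives > 100 ug/mL, which is a limit. It stands at the limit of > 100 ug/mL in this assay, at which 2 of the 3 values shown sit. Compound 2 alone stands at the other end, at the limit of < 1 ug/mL in this assay, at which 1 of the 3 values shown sits.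

The next compound is compound 4 `COc1ccc(C2=C(c3cc(OC)c(OC)c(OC)c3)C(=O)C(O)C2)cc1`. It differs from compound 3 by hydrogen in place of allyloxy on an aromatic carbon, with hydrogen in place of allyloxy on an aromatic carbon, ortho to a methoxy group.

Among the compounds with values here, no measured pair isolates this change, so its size in this assay can only be expected. The expectation is a large move toward stronger inhibition, beyond the usual scatter, and it rests on three compounds only. Its main support is compound 2 at < 1 ug/mL, a limit.

The estimated change is an at least 160-fold lower number from compound 3 to compound 4 (2.22 log units; beyond the scatter). Compound 4 is estimated at 0.6 ug/mL, with an expected range of 0.05 ug/mL to 15 ug/mL.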

Compound 4, half-maximal inhibitory concentration: < 1 ug/mL
Compound 4 ended at the assay's limit; the forecaster's own chance of this, stated with the estimate: 45%; the middle value lies beyond the limit too.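

In this assay, within the data shown here, hydrogen in place of allyloxy on an aromatic carbon, ortho to a methoxy group, gives an at least 100-fold lower number from compound 3 to compound 4 (2.00 log units; beyond the scatter), the first readable single-place step. This position therefore matters on this read-out, as allyloxy is the only difference between the two compounds, and the step lies beyond the usual scatter. Compound 4 now shares the lower limit with compound 2: the limit of < 1 ug/mL in this assay, at which 2 of the 4 values shown sit.

On these data alone, the step between compound 2 and compound 4, hydrogen in place of acetyl on an oxygen on a saturated carbon, cannot be read from two limits, so any effect of that change stays open. An ethoxy group, a longer chain or an amine on the aromatic carbon would show whether the step belongs to allyloxy alone or to other groups there as well.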